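This account rests on a few compounds, and the source may have more. Where it says the series, first, only, none or still open, it means among the compounds named here.

Measured so far in an ADME assay on the whole organism for cytotoxicity, with Artemia salina as the target, with a stated time of 24 h; on this read-out lower numbers stand for an effect already at smaller amounts and higher numbers for an effect only at larger amounts of compound:

Compound 1, `Cc1ccc(S(=O)(=O)NC(=O)Nc2ccccc2C(=O)/C=C/c2ccccc2)cc1`, gives 25 ug/mL.
Compound 2, `Cc1ccc(S(=O)(=O)NC(=O)Nc2ccccc2C(=O)/C=C/c2ccccc2[N+](=O)[O-])cc1`, gives 40.1 ug/mL.
Compound 3, `Cc1ccc(S(=O)(=O)NC(=O)Nc2ccccc2C(=O)/C=C/c2ccc(F)cc2)cc1`, gives 3.96 ug/mL.

Compound 3 stands lowest of these three numbers. The gap is shown by a 6.3-fold lower number from compound 1 to compound 3 (0.80 log units; beyond the scatter) and by a 10-fold lower number from compound 2 to compound 3 (1.01 log units; beyond the scatter), so compound 3 acts at smaller amounts than either of the other two, and both gaps lie beyond the scatter. Compound 1 and compound 2 differ from each other only by a 1.6-fold higher number from compound 1 to compound 2 (0.21 log units; within the scatter), which stays within the scatter.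

Compound 4, `Cc1ccc(S(=O)(=O)NC(=O)Nc2ccccc2C(=O)/C=C/c2ccc(Cl)cc2)cc1`, is the next compound. It differs from compound 3 by chloro in place of fluoro on an aromatic carbon. Among the measured steps, only the one from compound 1 to compound 3 touches this same position, where fluoro in place of hydrogen gave a modest step to a lower number. Among the measured compounds shown here, no measured step exchanges one halogen for another, so the data give no direct guide to swapping fluoro for chloro; a step of modest size in either direction, or none beyond the scatter, remains possible. Compound 4 is therefore expected to give 4.5 ug/mL, with a range from 1.5 ug/mL to 13 ug/mL. This estimate means a 1.1-fold higher number from compound 3 to compound 4 (0.06 log units; within the scatter), a change expected to stay close to compound 3.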

Compound 4, concentration for half-maximal effect: 6.92 ug/mL
Beside the measured number, compound 4's estimate is 1.5-fold (0.19 log units) below it, and the stated range covers the measured number.
By their numbers in this assay, from the lowest: compounds 3 and 4 (each within the scatter of the next); then compounds 1 and 2 (each within the scatter of the next).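

In this assay the swap of halogen on the aromatic ring, at the position para to a large group, gives a 1.7-fold higher number from compound 3 to compound 4 (0.24 log units; within the scatter) and so does not separate chloro from fluoro, where only fluoro had been seen before. Chloro in place of hydrogen gives a 3.6-fold lower number from compound 1 to compound 4 (0.56 log units; beyond the scatter) and 4-chlorophenyl in place of 2-nitrophenyl gives a 5.8-fold lower number from compound 2 to compound 4 (0.76 log units; beyond the scatter) as well, so the move to a lower number is no longer tied to fluoro alone but is shared by two halogens at this position. Compound 2 goes against any wider reading that every added ring group lowers the number, since its nitro group, on the same kind of ring but named at a different place, gives a step from compound 1 that stays within the scatter.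

Nothing shown explains why the two halogens give such similar numbers here. Still open, going by these compounds, is whether bromo, a methoxy group, an amine or a carboxylic acid at this same position would keep the number low, and whether a halogen is needed there at all.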